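From 2,5-difluorobenzyl to methyl on a shared core

This account rests on a few compounds, and the source may have more. Where it says the series, first, only, none or still open, it means among the compounds named here.

In a functional assay on Bel-7402 cells (Homo sapiens) for antiproliferative activity, read by MTT assay, with a stated time of 72 h (on this read-out lower numbers stand for stronger inhibition and higher numbers for weaker inhibition), compound 1 `C=C1C(=O)O[C@H]2[C@H]1CC/C(COC(=O)Cn1cc(F)c(=O)n(Cc3ccccc3F)c1=O)=C\CC[C@@]1(C)O[C@@H]21` gives 3770 nM and compound 2 `C=C1C(=O)O[C@H]2[C@H]1CC/C(COC(=O)Cn1cc(F)c(=O)n(Cc3cc(F)ccc3F)c1=O)=C\CC[C@@]1(C)O[C@@H]21` gives 3060 nM as its read-out. These two numbers lie within the scatter of each other, so compound 2 stands level with compound 1. Within the data shown here, the only measured step is a 1.2-fold lower number from compound 1 to compound 2 (0.09 log units; within the scatter) for a fluoro in place of hydrogen on an aromatic carbon. Compound 3 `C=C1C(=O)O[C@H]2[C@H]1CC/C(COC(=O)Cn1cc(F)c(=O)n(C)c1=O)=C\CC[C@@]1(C)O[C@@H]21` keeps the shared core and differs from compound 2 by hydrogen in place of 2,5-difluorophenyl on a saturated chain carbon bound to an aromatic nitrogen as one change, hydrogen in place of 2,5-difluorophenyl on a saturated chain carbon bound to an aromatic nitrogen, which turns 2,5-difluorobenzyl into methyl. Among the measured compounds shown here, compound 2 differs from compound 1 by a 1.2-fold lower number from compound 1 to compound 2 (0.09 log units; within the scatter) through one fluoro alone, whereas compound 3 loses the whole aromatic group, and no measured pair shows what that loss does in this assay on its own. A modest step toward a higher number is therefore expected, with a wide margin. The expected change is a 1.8-fold higher number from compound 2 to compound 3 (0.25 log units; within the scatter) on this estimate. For compound 3 the estimated value is 5500 nM with 2000 nM to 14000 nM as the expected range.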

Compound 3, half-maximal inhibitory concentration: 9400 nM
Compound 3: the middle estimate sits 1.7-fold (0.23 log units) below what was measured; measured number inside the range.
By their numbers in this assay, from the lowest: compounds 2 and 1 (each within the scatter of the next); then compound 3.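

In this assay, replacing the whole aromatic group at this position gives a step that can be read: 2,5-difluorobenzyl to methyl brings a 3.1-fold higher number from compound 2 to compound 3 (0.49 log units; beyond the scatter) and the matching loss of 2-fluorophenyl brings a 2.5-fold higher number from compound 1 to compound 3 (0.40 log units; beyond the scatter) and both lie beyond the scatter. The earlier fluoro step lay within the scatter, so only now does the saturated chain carbon bound to an aromatic nitrogen show that what it carries matters in this assay: the two compounds with a fluorinated phenyl group sit level with each other, and the methyl compound 3 has the higher number, though both steps are modest. Nothing at hand explains why the loss of the aromatic ring moves the number in this direction.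

Among these compounds, the three compounds show only two fluorinated benzyl groups and a methyl, so they cannot separate the effect of the ring itself from that of the fluorines on it or of the size of the group. An unsubstituted benzyl, a longer chain such as butyl, or a chain ending in an amine or a carboxylic acid would each be needed to settle what this position accepts.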